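Dimethylamino in place of methoxy: compound 1 to compound 4

A few compounds are considered here, and "the series" means these few. Any claim that something is new, unique, unknown or untested is made for them only; others in the source may bear on it.

Measured so far in a functional assay on HCT-116 cells (Homo sapiens) for inhibition, read by MTT assay, with a stated time of 48 h; a lower number here means a stronger inhibitor, a higher number a weaker inhibitor:
- compound 1 `CCSc1nnc(-c2cc(OC)c(OC)c(OC)c2)n1-c1ccc(OC)cc1` gives > 60000 nM
- compound 2 `COc1ccc(-n2c(SCC(=O)c3ccc(OC)c(O)c3)nnc2-c2cc(OC)c(OC)c(OC)c2)cc1` gives > 60000 nM
- compound 3 `COc1ccc(NC(=O)CSc2nnc(-c3cc(OC)c(OC)c(OC)c3)n2-c2ccc(OC)cc2)cc1` gives > 60000 nM

Compound 1 gives > 60000 nM as a limit and not a number. Compounds 2 and 3 are limits too, and the evidence across the set is the limit of > 60000 nM in this assay, at which 3 of the 3 values shown sit, and nothing firmer.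

Compound 4 `CCSc1nnc(-c2cc(OC)c(OC)c(OC)c2)n1-c1ccc(N(C)C)cc1` carries dimethylamino in place of methoxy on an aromatic carbon, para to a large group. The counted change is dimethylamino in place of methoxy on an aromatic carbon and the core of compound 1 stays.

The measured steps are a step that the two limits leave unreadable from compound 1 to compound 2 and a step that the two limits leave unreadable from compound 1 to compound 3 and a step that the two limits leave unreadable from compound 2 to compound 3 and all three alter the chain on sulfur, so none gives a size to carry over. No step beyond the scatter is expected in this assay and no direction can be set, so the expected step is an at least 1.2-fold lower number from compound 1 to compound 4 (0.07 log units; that floor lies within the scatter) as estimated.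

Compound 4 is estimated at 50000 nM with a range of 15000 nM to 90000 nM as expected values.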

Compound 4, half-maximal inhibitory concentration: > 60000 nM
Compound 4 was reported as a limit; the forecaster's own chance of this, stated with the estimate: 60%; middle value at least 1.2-fold (0.07 log units) away from the limit.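

In this assay compound 4 gives > 60000 nM, a limit and not a number. Within the data shown here, compound 1 gives > 60000 nM, also a limit, so no step between compound 1 and compound 4 can be read. The compounds shown leave open whether dimethylamino or methoxy gives the lower number, and whether any compound here has a measurable value in this assay.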